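The source may report more compounds than this note shows. Statements on the series, on what has been measured and on what is new or still open speak of the compounds shown alone.

Compound 1 `C/C(=N\NC(=O)COc1cccc2ccccc12)c1ccc(C#N)cc1Br` shares its core with compound 2 `COc1ccc(/C=N/NC(=O)COc2cccc3ccccc23)cc1O` and compound 3 `COc1cc(/C=N/NC(=O)COc2cccc3ccccc23)cc(OC)c1OC`. In an ADME assay on HEL cells (Homo sapiens) for cytotoxicity (on this read-out higher numbers stand for lower toxicity in this test and lower numbers for higher toxicity in this test), compound 1 gives 20 ug/mL, the lowest of the two numbers available here. In this assay compound 2 gives 100 ug/mL, a gap from compound 1 that is beyond the scatter. Compound 3 reports only a limit of this assay, namely >= 20 ug/mL. That reading sits at the limit of >= 20 ug/mL in this assay, at which 1 of the 3 values shown sits. Among the compounds with values here, no pair of measured compounds differs in a single place, so no measured step is available.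

Compound 4 `C/C(=N\NC(=O)COc1cccc2ccccc12)c1ccc(O)cc1O` is the next compound for this assay. It differs from compound 1 thus: 2,4-dihydroxyphenyl in place of 2-bromo-4-cyanophenyl on a carbon with a double bond to nitrogen.

Within the data shown here, with no measured single-place step, the expectation rests only on the spread of the two numbers. Among the measured compounds shown here, compound 4 is expected to move away from compound 1 toward lower toxicity, a step of a 3.0-fold higher number from compound 1 to compound 4 (0.48 log units; beyond the scatter), since the only other number in the set, compound 2 at 100 ug/mL, lies higher. Compound 4 is therefore estimated at 60 ug/mL, with a range from 20 ug/mL to 100 ug/mL.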

Compound 4, minimum cytotoxic concentration: > 100 ug/mL
Compound 4 gave a limit, no number; the forecaster's own chance of this, stated with the estimate: 40%; middle value at least 1.6-fold (0.22 log units) from the limit.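

Within the data shown here, the first single-place step in this assay comes at the substituted phenyl on a carbon with a double bond to nitrogen, where 2,4-dihydroxyphenyl in place of 2-bromo-4-cyanophenyl gives an at least 5.0-fold higher number from compound 1 to compound 4 (0.69 log units; beyond the scatter). Among these compounds, this shows that a change at this one place, with the rest of the core of compound 1 kept, moves the read-out beyond the scatter toward lower toxicity in this test, which the earlier compounds, differing in more than one place, could not show. Compound 4 gives > 100 ug/mL, which is a limit and not a number: the limit of > 100 ug/mL in this assay, at which 1 of the 4 values shown sits.

From the compounds shown here alone, the change swaps all the ring substituents at once, so it stays open whether the loss of the bromine, the loss of the nitrile or the gain of either hydroxyl accounts for the step. Also open, going by these compounds, is how an amine or a carboxylic acid on this phenyl would read in this assay.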